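Taking the benzoyl off compound 2

This account rests on a few compounds, and the source may have more. Where it says the series, first, only, none or still open, it means among the compounds named here.

- Compound 1 `CCCCCCCCCc1ccc(OP(=O)(O)OC[C@H]2O[C@@H](n3cc(F)c(=O)[nH]c3=O)C[C@@H]2OC(=O)c2ccccc2)cc1` gives > 120 h as a limit of the assay, not an exact number
- Compound 2 `O=C(O[C@H]1C[C@H](n2cc(F)c(=O)[nH]c2=O)O[C@@H]1COP(=O)(O)Oc1ccc2ncccc2c1)c1ccccc1` gives 16.5 h as an exact reading

Both results come from an ADME assay on a cell-free system (serum, Homo sapiens) for metabolic stability, read by HPLC, tested at 2 mM (a higher number here means that the compound lasts longer, a lower number that the compound disappears faster), and describe how long each compound survives there. Among the measured compounds shown here, compound 2 at 16.5 h holds the only exact number so far, so it is the sole firm reference point.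

Compound 3 `O=c1[nH]c(=O)n([C@H]2C[C@H](O)[C@@H](COP(=O)(O)Oc3ccc4ncccc4c3)O2)cc1F` has not yet been measured. It differs from compound 2 by a single change: hydrogen in place of benzoyl on an oxygen on a saturated carbon. In words, hydrogen takes the place of benzoyl on an oxygen on a saturated carbon, turning benzoyloxy into hydroxy.

For the measured compounds named here, no measured step shows what this change does in this assay. The data therefore favour no direction, and no shift beyond the usual scatter is expected. The expected step is a 1.1-fold higher number from compound 2 to compound 3 (0.04 log units; within the scatter) and its uncertainty is wide. For compound 3 the estimated half-life is 18 h, with an expected range from 6 h to 55 h.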

Compound 3, half-life in the Homo sapiens assay: 26.2 h
Estimate against measurement, compound 3: 1.5-fold (0.16 log units) below, within the range that was stated.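

Among the compounds shown here, this is the first measured step at this oxygen, and in the Homo sapiens assay hydrogen in place of benzoyl gives a 1.6-fold higher number from compound 2 to compound 3 (0.20 log units; within the scatter), with compound 2 at 16.5 h and compound 3 at 26.2 h, so on this read-out the two compounds cannot be told apart. In a physicochemical assay for metabolic stability, read by HPLC, tested at 2 mM (on this read-out lower numbers stand for a shorter-lived compound and higher numbers for a longer-lived compound), the same change gives a 3.4-fold higher number from compound 2 to compound 3 (0.53 log units; beyond the scatter), with compound 2 at 7.7 h and compound 3 at 26 h, a modest result that rests on this single pair. The swap from benzoyloxy to hydroxy therefore clears the usual scatter on only one of the two read-outs, which a single assay could not have shown.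

The compounds shown leave open how a smaller acetyl ester or an amine would behave on this same saturated carbon. From the compounds shown here alone, in the Homo sapiens assay compound 1 gives > 120 h, which is a limit of the assay, so the size of this change on the core of compound 1 also remains open.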